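The compounds below may be only part of what the source reports. "The series", "measured", "known", "first", "only" and "open" are said of these compounds alone.

Measured compounds:
compound 1 `Cc1ccc(-c2ccccc2S(=O)(=O)N2CCC(N3CCC(C)CC3)CC2)cc1`: > 5000 nM
compound 2 `Cc1ccc(S(=O)(=O)N2CCC(N3CCC(C)CC3)CC2)cc1C`: > 5000 nM
compound 3 `Cc1cc(C)c(S(=O)(=O)N2CCC(N3CCCCCC3)CC2)c(C)c1`: > 5000 nM

All three were tested in an ADME assay on HCT-116 cells (Homo sapiens) for cytotoxicity, read by CellTiter-Glo, with a stated time of 72 h (a higher number here means a weaker inhibitor, a lower number a stronger inhibitor), a measure of how strongly a compound holds back the growth of a human colon cancer cell line. Compound 1 gives only a limit there, > 5000 nM. For compound 2 the result is likewise a limit, > 5000 nM. Compound 3 also returns a limit, > 5000 nM. So compound 2 stands where every value shown stands: at the limit of > 5000 nM in this assay, at which 3 of the 3 values shown sit, with no number below it. All three rest on that same limit. For the measured compounds named here, no step between measured compounds can be sized.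

Compound 4 `CC1CCN(C2CCN(S(=O)(=O)c3ccc(Cl)nc3)CC2)CC1` is not yet measured. It differs from compound 2 in one place: 6-chloropyridin-3-yl in place of 3,4-dimethylphenyl on a sulfonyl sulfur. With nothing but limits among the measured compounds, no shift beyond the usual scatter is expected, and the step expected is a step that the limit leaves unreadable from compound 2 to compound 4. Compound 4 is therefore estimated to land around 10000 nM, between 3000 nM and 40000 nM, most likely again as a limit.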

Compound 4, half-maximal inhibitory concentration: > 10000 nM
Compound 4: a limit, no number; the forecaster's own chance of this, stated with the estimate: 85%; the middle value sits exactly at the limit.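

Compound 2 and compound 4 each return only a limit, not a number, so the step from 3,4-dimethylphenyl to 6-chloropyridin-3-yl cannot be read. The compounds shown leave open whether this assay can return an actual number for any group on the sulfonyl sulfur.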